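Swapping a five-membered azole on a shared indole-type core

A few compounds are considered here, and "the series" means these few. Any claim that something is new, unique, unknown or untested is made for them only; others in the source may bear on it.

Compound 1: `OC[C@H](NC1CCN(CCCc2c[nH]c3ccc(-n4ccnc4)cc23)CC1)c1ccccc1` — 0.7 nM
Compound 2: `C[C@@H](NC1CCN(CCCc2c[nH]c3ccc(-n4ccnc4)cc23)CC1)c1ccccc1` — 4.2 nM
Compound 3: `CN(Cc1ccco1)C1CCN(CCCc2c[nH]c3ccc(-n4cnnc4)cc23)CC1` — 9.3 nM

Of the compounds shown here, three have been tested in an assay on CHO cells for displacement of a labelled ligand from 5-hydroxytryptamine receptor 1D (Homo sapiens); on this read-out higher numbers stand for weaker inhibition and lower numbers for stronger inhibition. Compound 1 gives the lowest number of the three, 0.7 nM. For the measured compounds named here, compound 2 follows, and the single change between them is a clear step: a 6.0-fold higher number from compound 1 to compound 2 (0.78 log units; beyond the scatter). Compound 3 gives 9.3 nM; it differs from compound 1 in more than one place, so its value says little on its own about any single change.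

The new compound is compound 4, `OC[C@H](NC1CCN(CCCc2c[nH]c3ccc(-n4cncn4)cc23)CC1)c1ccccc1`. It keeps the whole of compound 1 except for one group on the shared core: 1H-1,2,4-triazol-1-yl in place of 1H-imidazol-1-yl on an aromatic carbon. Going by the values given here, no measured pair isolates this kind of change; the one measured step concerns the amine side instead. The best that can be said is that the two ring systems are of the same size and shape and differ by one ring atom, so a large shift is not anticipated.

The estimate for compound 4 in this assay is 1.2 nM, with a likely range of 0.4 nM to 4 nM. That estimate corresponds to a 1.7-fold higher number from compound 1 to compound 4 (0.23 log units; within the scatter), a step expected to lie within the ordinary scatter.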

Compound 4, half-maximal inhibitory concentration: 4.1 nM
For compound 4 the middle estimate is 3.4-fold (0.53 log units) below the measured one; measured number above the stated range.
By their numbers in this assay, from the lowest: compound 1; then compounds 4 and 2 (each within the scatter of the next); then compound 3.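

In this assay, for the compounds shown here, replacing 1H-imidazol-1-yl with 1H-1,2,4-triazol-1-yl on the aromatic carbon of the shared core produces a measurable change (a 5.9-fold higher number from compound 1 to compound 4 (0.77 log units; beyond the scatter)), the first direct reading for this position. Both rings have 5 heavy atoms and are five-membered and aromatic, with the entering ring holding 3 hetero atoms where the leaving ring holds 2, so even this close exchange separates the two compounds by more than the scatter and the two azoles cannot be treated as interchangeable here. The step is modest, the same grade as the change on the amine side (a 6.0-fold higher number from compound 1 to compound 2 (0.78 log units; beyond the scatter)), and no accompanying measurement offers an explanation for the effect of the ring exchange.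

The compounds shown do not reveal whether the same exchange would cost a similar amount with the 1-phenylethyl group on the amine nitrogen, since that pairing is absent here. They also leave open how this position would respond to a different group on the same aromatic carbon, such as 1H-pyrazol-1-yl, a tetrazole ring or a nitrile.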